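Replacing isobutylamino with 4-methylpiperazin-1-yl in the series

The source may report more compounds than this note shows. Statements on the series, on what has been measured and on what is new or still open speak of the compounds shown alone.

compound 1 `CN(C)C(=O)CCC(=O)c1cccc(C(F)(F)F)c1` gives > 50 mg/kg as a limit
compound 2 `CC(C)NC(=O)CCC(=O)c1cccc(C(F)(F)F)c1` gives > 200 mg/kg as a limit
compound 3 `CC(C)CNC(=O)CCC(=O)c1cccc(C(F)(F)F)c1` gives > 200 mg/kg as a limit

All three entries are limits in a functional assay on the whole organism with Mus musculus as the target (a lower number here means that less compound is needed, a higher number that more compound is needed for the effect), and not numbers. Compound 3 therefore stands only at its limit of > 200 mg/kg. The next step puts 4-methylpiperazin-1-yl in place of isobutylamino on a carbonyl carbon to give compound 4 `CN1CCN(C(=O)CCC(=O)c2cccc(C(F)(F)F)c2)CC1`, with this counted difference: 4-methylpiperazin-1-yl in place of isobutylamino on a carbonyl carbon.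

The measured steps at the same place are a step that the two limits leave unreadable from compound 1 to compound 2, a step that the two limits leave unreadable from compound 1 to compound 3 and a step that the two limits leave unreadable from compound 2 to compound 3. None has a readable size. The series offers only the limit of > 200 mg/kg in this assay, at which 2 of the 3 values shown sit, and (the limit of > 50 mg/kg in this assay, at which 1 of the 3 values shown sits). No direction can be drawn from these steps, so the expectation is weak and rests on the limits alone. The expected change is a number no higher from compound 3 to compound 4 (the limit leaves the size open), and this size is only loosely estimated. Compound 4 is estimated at 200 mg/kg, with an expected range from 70 mg/kg to 500 mg/kg and a good chance that only a limit is reported.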

Compound 4, dose for half-maximal effect: > 50 mg/kg
Compound 4: no number, only a limit; the forecaster's own chance of this, stated with the estimate: 70%; the middle value does not contradict the limit.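

In this assay, for the compounds shown here, compound 4 gives > 50 mg/kg, a limit and not a number, so no step linking it to compound 1, compound 2 or compound 3 can be read. The compounds shown leave open whether 4-methylpiperazin-1-yl changes the dose relative to dimethylamino, isopropylamino or isobutylamino.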